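The source may hold more compounds than are shown below. What is called first, only, known or untested is meant among the compounds shown, and "the series" means these compounds.

Measured so far:
Compound 1 `C[C@@H]1CN(c2cccc3c2C[C@H](CN(C)[C@H]2CCCc4cccnc42)NC3)C[C@H](C)N1` gives in a functional assay on CCRF-CEM cells for agonist activity at C-X-C chemokine receptor type 4 (Homo sapiens), read by calcium flux, with a stated time of 25 min (on this read-out higher numbers stand for an effect only at larger amounts of compound and lower numbers for an effect already at smaller amounts), a reading of > 30000 nM, which is a limit of the assay and not a number.
Compound 2 `C[C@@H]1CN(c2cccc3c2C[C@H](CN(C)[C@H]2CCCc4cccnc42)NC3)C[C@H](C)N1C` gives in this assay > 30000 nM, again a limit of the assay and not a number.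

Compound 2 therefore stands only at a limit in this assay. Among the measured compounds shown here, the one further value shown is also a limit, so the change a step that the two limits leave unreadable from compound 1 to compound 2 cannot be read, and the limit of > 30000 nM in this assay, at which 2 of the 2 values shown sit, is all that the two values tell. Compound 3 `CN(C[C@H]1Cc2c(cccc2N2C[C@H]3C[C@@H]2CN3)CN1)[C@H]1CCCc2cccnc21` has not yet been measured in this assay. It differs from compound 2 in a group of 7 heavy atoms (5 carbon, 2 nitrogen; 2 five-membered non-aromatic rings with 1 hetero atom each) in place of a group of 9 heavy atoms (7 carbon, 2 nitrogen; one six-membered non-aromatic ring with 2 hetero atoms), on an aromatic carbon. For the measured compounds named here, the only measured step touches this change merely in that both of its ends sit at a limit, so it gives neither a size nor a direction for the move to compound 3. On this footing compound 3 is expected to sit once more at the limit of the assay, with an estimated value of 40000 nM. The range of that expectation for compound 3 runs from 8000 nM to 200000 nM. The step that the limit leaves unreadable from compound 2 to compound 3 is accordingly expected to be none beyond the scatter.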

Compound 3, half-maximal effective concentration: > 30000 nM
Compound 3 ended at the assay's limit (the forecaster's own chance of this, stated with the estimate: 85%); the middle value lies beyond the limit too.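

Compound 3, like compound 1 and compound 2, stands only at a limit of this assay, so no step among these three compounds can be read: the limit of > 30000 nM in this assay, at which 3 of the 3 values shown sit.

The compounds shown leave open whether the methyl on the ring amine nitrogen, or the exchange of the ring group on the aromatic carbon, shifts the half-maximal effective concentration, and in which direction.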